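The compounds below may be only part of what the source reports. "The series", "measured", "known", "first", "only" and "open" are said of these compounds alone.

Measured so far in an assay on HEK cells for antagonist activity at transient receptor potential cation channel subfamily V member 1 (Homo sapiens), read by FLIPR; a lower number here means a stronger inhibitor, a higher number a weaker inhibitor:
compound 1 `O=C(NCc1ccc(C(F)(F)F)nc1N1CCCCC1)Nc1cccc2[nH]c(=O)ccc12` — 0.75 nM
compound 2 `CC(C)COc1nc(C(F)(F)F)ccc1CNC(=O)Nc1cccc2[nH]c(=O)ccc12` — 2.6 nM
compound 3 `O=C(NCc1ccc(C(F)(F)F)nc1OCC1CCC1)Nc1cccc2[nH]c(=O)ccc12` — 1.49 nM

Compound 1 gives the lowest of the three numbers. Its nearest neighbour is compound 3, a 2.0-fold higher number from compound 1 to compound 3 (0.30 log units; within the scatter), a step within the scatter; the furthest is compound 2, a 3.5-fold higher number from compound 1 to compound 2 (0.54 log units; beyond the scatter), a modest step beyond the scatter. Between the two ethers, a 1.7-fold lower number from compound 2 to compound 3 (0.24 log units; within the scatter), again within the scatter.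

Compound 4 `CC1CCC(c2nc(C(F)(F)F)ccc2CNC(=O)Nc2cccc3[nH]c(=O)ccc23)CC1` is not yet measured. Relative to compound 1 the change is: 4-methylcyclohexyl in place of piperidin-1-yl on an aromatic carbon

The two steps that bear on this are those from compound 1 to the ethers, where piperidin-1-yl was exchanged for isobutoxy or cyclobutylmethoxy: both gave higher numbers, one within and one beyond the scatter. Nothing measured yet carries a ring of carbon only at this aromatic carbon, so the direction is taken from those two steps. A modest rise in this assay is expected for compound 4, a 2.7-fold higher number from compound 1 to compound 4 (0.43 log units; beyond the scatter), most likely a little beyond the scatter. Compound 4 is estimated at 2 nM, in the range 0.6 nM to 7 nM.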

Compound 4, half-maximal inhibitory concentration: 1.44 nM
For compound 4 the middle estimate is 1.4-fold (0.14 log units) above the measured one, and the stated range covers the measured number.
By their numbers in this assay, from the lowest: compounds 1, 4, 3 and 2 (each within the scatter of the next, the first and the last beyond it).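

In this assay, 4-methylcyclohexyl on this aromatic carbon, next to the ring nitrogen, shows that the site does not depend on a nitrogen or oxygen attached to the ring: a 1.9-fold higher number from compound 1 to compound 4 (0.28 log units; within the scatter), a step within the scatter. Against the ethers, the readings are a 1.0-fold lower number from compound 3 to compound 4 (0.01 log units; within the scatter) and a 1.8-fold lower number from compound 2 to compound 4 (0.26 log units; within the scatter), both also within the scatter, so a ring of carbon only cannot be told apart from piperidin-1-yl, cyclobutylmethoxy or isobutoxy here. No measurement is available that would explain this tolerance.

Still open, from the compounds shown here alone, is whether plain cyclohexyl reads the same as 4-methylcyclohexyl, which would show what the methyl contributes. Also open, going by these compounds, is whether a morpholin-4-yl group or a carboxylic acid on this carbon stays within the same narrow band.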